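A few compounds are considered here, and "the series" means these few. Any claim that something is new, unique, unknown or untested is made for them only; others in the source may bear on it.

Working notes on the series in a functional assay on 1A9 cells (Homo sapiens) for cytotoxicity; a lower number here means that less compound is needed, a higher number that more compound is needed for the effect. Within the data shown here, compound 1 `COC1=C(C)C(=O)/C(=C(O)/C=C/c2ccc(OC)cc2)C(=O)C1(C)C` gives 2.8 ug/mL, the only number available. Compound 2 `COC1=C(C)C(=O)/C(=C(O)/C=C/c2ccc(C)cc2)C(=O)C1(C)C` is recorded as "not determined" (no result reported). Compound 3 `COC1=C(C)C(=O)/C(=C(O)/C=C/c2c(C)cccc2C)C(=O)C1(C)C` is recorded as "not determined" (no result reported), so compound 3 has no single number and cannot be placed against compound 1. Compound 4 `COC1=C(C)C(=O)/C(=C(O)/C=C/c2nccs2)C(=O)C1(C)C` has not yet been measured. The structural change is 1,3-thiazol-2-yl in place of 2,6-dimethylphenyl on a double-bonded chain carbon bound to a double-bonded chain carbon, with 1,3-thiazol-2-yl in place of 2,6-dimethylphenyl on a double-bonded chain carbon. Among the measured compounds shown here, no measured step exists to carry over, so the only anchor is compound 1 at 2.8 ug/mL, and no shift from it beyond the usual scatter is expected, in either direction. For compound 4 the estimated value is 3 ug/mL, with an expected range of 1 ug/mL to 10 ug/mL.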

Compound 4, concentration for half-maximal effect: 3.5 ug/mL
Estimate against measurement, compound 4: 1.2-fold (0.07 log units) below; measured number inside the range.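

In this assay, among these compounds, the change gives a 1.3-fold higher number from compound 1 to compound 4 (0.10 log units; within the scatter), the first readable step at this position: on a double-bonded chain carbon bound to a double-bonded chain carbon, 1,3-thiazol-2-yl and 4-methoxyphenyl cannot be told apart. A five-membered aromatic ring with 2 hetero atoms therefore serves here as well as the substituted six-membered ring, though no measurement on hand accounts for this. Steps involving compound 2 or compound 3 cannot be read.

Still open, going by these compounds, is whether an aminomethyl or carboxylic acid group on the aromatic ring would shift the number. A cyclohexyl group in this place is equally untested in the compounds shown.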